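A few compounds are considered here, and "the series" means these few. Any claim that something is new, unique, unknown or untested is made for them only; others in the source may bear on it.

Compound 1 `Nc1ccccc1NC(=O)c1ccc(Cn2cnc3c(NCc4ccccc4)nc(Cl)nc32)cc1` carries a (2-aminophenyl)carbamoyl group on the benzyl ring of the shared core. In a functional assay on NCI-H460 cells (Homo sapiens) for antiproliferative activity, read by CCK-8 assay, with a stated time of 72 h, tested at 2 uM (on this read-out higher numbers stand for a stronger effect at the one concentration tested and lower numbers for a weaker effect), compound 1 gives 44.7%, the higher of the two numbers in hand. Compound 2 `CN1CCN(c2nc(Cl)nc3c2ncn3Cc2ccc(C(=O)Nc3ccccc3N)cc2)CC1` has 4-methylpiperazin-1-yl in place of benzylamino on an aromatic carbon; in this assay compound 2 gives 13.5%, and the step from one to the other is a number 31.2 percentage points lower from compound 1 to compound 2 (beyond the scatter). Compound 3 `Nc1ccccc1NC(=O)/C=C/c1ccc(Cn2cnc3c(NCc4ccccc4)nc(Cl)nc32)cc1` differs from compound 1 at another place: 2-((2-aminophenyl)carbamoyl)ethenyl in place of (2-aminophenyl)carbamoyl on an aromatic carbon. Among the compounds with values here, no measured step touches this group; the single step in hand concerns the benzylamino group on the core and says nothing about exchanging (2-aminophenyl)carbamoyl for 2-((2-aminophenyl)carbamoyl)ethenyl. The expectation therefore rests on the value of compound 1 alone, and the step expected is a number 0.3 percentage points higher from compound 1 to compound 3 (within the scatter), which is not expected to go beyond the scatter. Compound 3 is estimated at 45% in this assay, with a wide expected range from 25% to 65%.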

Compound 3, a percentage reported as inhibition, at one concentration (the size of the read-out at that concentration, not a potency): 4.62%
Estimate against measurement, compound 3: 40.4 percentage points above, outside the stated range (below it).
By their numbers in this assay, from the lowest: compounds 3 and 2 (each within the scatter of the next); then compound 1.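

In this assay, the step of a number 40.1 percentage points lower from compound 1 to compound 3 (beyond the scatter) shows that the position para to a large group, on the six-membered aromatic ring of carbon only, is sensitive to extension: 2-((2-aminophenyl)carbamoyl)ethenyl does not serve as a neutral replacement for (2-aminophenyl)carbamoyl. Within the data shown here, the only earlier step concerned the benzylamino group on the shared core, so this is the first sign that the read-out also depends strongly on this second site, even though the aromatic ring and the counts of hydrogen-bond donors and acceptors stay the same and the change consists of added carbon and one more double bond outside aromatic rings. No measurement in hand bears on the reason for this loss.

The compounds shown do not separate the effect of the double bond from that of the added length, a question that a saturated chain of the same length at this position could address. Going by these compounds, it also remains open whether the loss is specific to the 2-aminophenyl amide, or would also appear with a hydroxamic acid carried on the same ethenyl group.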